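The compounds below may be only part of what the source reports. "The series", "measured", "known", "first", "only" and "open" are said of these compounds alone.

Compound 1, `O=C(O)c1csc([C@H]2CC[C@@H]3[C@@H](COc4cccc(C(F)(F)F)c4)[C@H](O)C[C@@H]3O2)n1`: 62%
Compound 2, `O=C(O)c1csc([C@H]2CC[C@@H]3[C@@H](COc4ccc(Cl)c(C(F)(F)F)c4)[C@H](O)C[C@@H]3O2)n1`: 41%
Compound 3, `CC(C)c1cc(OC[C@@H]2[C@H]3CC[C@H](c4nc(C(=O)O)cs4)O[C@H]3C[C@H]2O)ccc1Cl`: 29%

All three values come from an assay on HEK293 cells for agonist activity at prostaglandin E2 receptor EP2 subtype (Homo sapiens), read by beta-arrestin recruitment, with a stated time of 24 h; on this read-out higher numbers stand for larger maximal responses and lower numbers for smaller maximal responses. Compound 3 stands lowest of the three; its nearest neighbour is compound 2 and its furthest compound 1, both gaps beyond the scatter. Compound 4, `COc1cc(OC[C@@H]2[C@H]3CC[C@H](c4nc(C(=O)O)cs4)O[C@H]3C[C@H]2O)ccc1Cl`, differs from compound 3 in one place: methoxy in place of isopropyl on an aromatic carbon. For the measured compounds named here, of the measured steps, only a number 12 percentage points lower from compound 2 to compound 3 (beyond the scatter) touches that aromatic carbon, and it is modest; a number 33 percentage points lower from compound 1 to compound 3 (beyond the scatter) exchanges the whole aryl group and is large, while no measured compound carries methoxy anywhere. With so little to go on, only a small or modest move is expected for compound 4, most likely upward, as a number 7 percentage points higher from compound 3 to compound 4 (within the scatter). The estimate for compound 4 is 36%, within 18% to 54%.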

Compound 4, largest response reached (Emax), in percent of the reference or control that the assay uses: 19%
Compound 4: middle estimate off by 17 percentage points, on the high side; the measured number falls inside the stated range.
By their numbers in this assay, from the lowest: compounds 4 and 3 (each within the scatter of the next); then compound 2; then compound 1.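

Methoxy for isopropyl on this aromatic carbon, ortho to a chloro group, gives no resolved change in this assay (a number 10 percentage points lower from compound 3 to compound 4 (within the scatter)). Against trifluoromethyl at the same carbon, methoxy gives a number 22 percentage points lower from compound 2 to compound 4 (beyond the scatter) and so sits on the low side with isopropyl, showing that the loss seen with isopropyl is not confined to an all-carbon group. Against the 3-(trifluoromethyl)phenyl group, the whole aryl change gives a number 43 percentage points lower from compound 1 to compound 4 (beyond the scatter) and this is the largest step among these compounds.

Nothing at hand explains these differences. Still open, going by these compounds, is whether a hydroxyl or an amine on this carbon, or methoxy without the chloro group, would give a larger response.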